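The compounds below may be only part of what the source reports. "The series", "measured", "known", "first", "only" and "open" are said of these compounds alone.

Compound 1 `O=C(/C=C/c1cccc([N+](=O)[O-])c1)c1ccc(N2CCCCC2)cc1` — in an ADME assay on Vero cells (Chlorocebus sabaeus) for cytotoxicity, read by resazurin assay, with a stated time of 72 h (on this read-out lower numbers stand for higher toxicity in this test and higher numbers for lower toxicity in this test), compound 1 gives "not determined" (no result reported).
Compound 2 `O=C(/C=C/c1ccc([N+](=O)[O-])o1)c1ccc(-c2ccccc2)cc1` — compound 2 gives > 100000 nM, which is a limit of this assay rather than a number.
Compound 3 `CCCCc1ccc(C(=O)/C=C/c2ccc([N+](=O)[O-])o2)cc1` — compound 3 gives 75700 nM.

For the measured compounds named here, compound 3 therefore stands with the only plain number among the three compounds: compound 2 reaches only a limit, and compound 1 has no result. A single measured step links two of them: an at least 1.3-fold lower number from compound 2 to compound 3 (0.12 log units; that floor lies within the scatter). That floor lies within the usual scatter, so the step shows no change that can be trusted. The reading the limit of > 100000 nM in this assay, at which 1 of the 3 values shown sits, marks the only boundary seen in this assay.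

Compound 4 `O=C(/C=C/c1ccc([N+](=O)[O-])o1)c1ccc(Br)cc1` differs from compound 3 in one place: bromo in place of butyl on an aromatic carbon. The step from compound 2 to compound 3 concerns the same position but exchanges phenyl for butyl, not butyl for bromo, so it offers only weak guidance, and it showed no change beyond the scatter. Going by the values given here, none of the measured compounds carries a bromo group. With nothing pointing either way, no step beyond the scatter is expected in this assay. Compound 4 is therefore estimated at 80000 nM, with a range from 30000 nM to 200000 nM. The estimated step is a 1.1-fold higher number from compound 3 to compound 4 (0.02 log units; within the scatter). Since one of three readings already sits at the limit, a further limit instead of a number remains a real possibility.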

Compound 4, half-maximal cytotoxic concentration: > 100000 nM
Compound 4 gave a limit, no number; the forecaster's own chance of this, stated with the estimate: 40%; middle value at least 1.2-fold (0.09 log units) from the limit.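

At this place on the six-membered aromatic ring, para to a large group, bromo in place of butyl gives in this assay an at least 1.3-fold higher number from compound 3 to compound 4 (0.12 log units; that floor lies within the scatter), so even a four-carbon chain exchanged for a single bromine atom shows no change that can be told apart from repeat scatter. This position now carries three different groups, and only butyl gives a plain number, while phenyl and bromo each give a limit, so a ring and a halogen end up at the same reading despite having little else in common. Compound 2 and compound 4 both sit at a limit, so the step between them cannot be read, and the limit now bounds much of what this series can show: the limit of > 100000 nM in this assay, at which 2 of the 4 values shown sit.

Going by these compounds, because of that limit, the true readings of compound 2 and compound 4 stay unknown, so it remains open whether butyl truly lowers the number at all: the limit of > 100000 nM in this assay, at which 2 of the 4 values shown sit. The compounds shown also leave open what an amine, a carboxylic acid or a chain longer than butyl would give at this position in this assay.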